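Series notes: diethylamino for bromo on compound 2

The source may report more compounds than this note shows. Statements on the series, on what has been measured and on what is new or still open speak of the compounds shown alone.

Compound 2 `COc1ccc(C(=O)/C=C/c2ccc(Br)cc2)c2c1C=CC(C)(C)O2` is known only by a limit: in a functional assay on SW-620 cells (Homo sapiens) for antiproliferative activity, read by MTT assay, with a stated time of 24 h (on this read-out higher numbers stand for weaker inhibition and lower numbers for stronger inhibition), compound 2 gives > 10000 nM. Compound 1 `COc1ccc(C(=O)/C=C/c2cccc(F)c2)c2c1C=CC(C)(C)O2` likewise sits at a limit, giving > 10000 nM in this assay. The step that the two limits leave unreadable from compound 1 to compound 2 is therefore unreadable, and the limit of > 10000 nM in this assay, at which 2 of the 2 values shown sit, is the only measured footing. Compound 3 `CCN(CC)c1ccc(/C=C/C(=O)c2ccc(OC)c3c2OC(C)(C)C=C3)cc1` differs from compound 2 by diethylamino in place of bromo on an aromatic carbon. No measured step bears on this change, so no size or direction of step in this assay can be read from the numbers shown. Compound 3 is estimated at 8000 nM, with a range from 1500 nM to 40000 nM, an expected step of an at least 1.2-fold lower number from compound 2 to compound 3 (0.09 log units; that floor lies within the scatter).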

Compound 3, half-maximal inhibitory concentration: 670 nM
Compound 3: middle estimate off by 12-fold (1.08 log units), on the high side, outside the stated range (below it).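

In this assay, among these compounds, diethylamino in place of bromo, on an aromatic carbon para to a large group, gives an at least 14-fold lower number from compound 2 to compound 3 (1.17 log units; beyond the scatter) as the first readable step. This place on the ring can therefore carry a change that moves the read-out, which compounds 1 and 2 could not show. The size of the step is only a floor, since compound 2 stands at a limit: the limit of > 10000 nM in this assay, at which 2 of the 3 values shown sit.

Going by these compounds, whether a smaller amine such as dimethylamino, or a plain butyl chain, at this place would also give a lower number remains open.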